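The compounds below may be only part of what the source reports. "The series", "measured", "known", "first", "only" and "open" are said of these compounds alone.

Compound 1 `Fc1cccc(-c2nc(Nc3ccccc3)c3cc(F)ccc3n2)c1` gives 48300 nM in a functional assay on HL-60 cells (Homo sapiens) for cytotoxicity, read by MTT assay, with a stated time of 48 h; on this read-out higher numbers stand for weaker inhibition and lower numbers for stronger inhibition.
Compound 2 `COc1ccc(Nc2nc(-c3cccc(F)c3)nc3ccc(F)cc23)cc1` gives 38600 nM in this assay.
Compound 3 `Fc1cccc(Nc2nc(-c3cccc(F)c3)nc3ccc(F)cc23)c1` gives 43100 nM in this assay.

Compound 3 stands among three numbers that all lie within the scatter of one another: a 1.1-fold higher number from compound 2 to compound 3 (0.05 log units; within the scatter) and a 1.1-fold lower number from compound 1 to compound 3 (0.05 log units; within the scatter). Compound 4 `Fc1cccc(-c2nc(Nc3ccccc3F)c3cc(F)ccc3n2)c1` differs from compound 3 by 2-fluorophenyl in place of 3-fluorophenyl on a nitrogen on an aromatic ring. The step that bears most on this change is the earlier swap on the same nitrogen, a 1.1-fold higher number from compound 2 to compound 3 (0.05 log units; within the scatter), which stayed within the scatter, as did a 1.3-fold lower number from compound 1 to compound 2 (0.10 log units; within the scatter). Among the measured compounds shown here, nothing among the measured compounds points to a shift in this assay beyond the scatter, so compound 4 is expected to land close to compound 3, with the estimated step of a 1.0-fold lower number from compound 3 to compound 4 (0.00 log units; within the scatter). Compound 4 is therefore estimated at 43000 nM, with a range from 20000 nM to 90000 nM.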

Compound 4, half-maximal inhibitory concentration: > 50000 nM
Compound 4: no number, only a limit; the forecaster's own chance of this, stated with the estimate: 10%; middle value at least 1.1-fold (0.06 log units) from the limit.
By their numbers in this assay, from the lowest: compounds 2, 3 and 1 (each within the scatter of the next). At a limit, above all of these: compound 4.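

In this assay, compound 4 gives only a limit of the assay, not a number, > 50000 nM. Moving the fluoro from 3-fluorophenyl to 2-fluorophenyl on this nitrogen is thus the first change here to end at that limit: the limit of > 50000 nM in this assay, at which 1 of the 4 values shown sits. The steps are an at least 1.1-fold higher number from compound 3 to compound 4 (0.06 log units; that floor lies within the scatter), an at least 1.2-fold higher number from compound 2 to compound 4 (0.11 log units; that floor lies within the scatter) and an at least 1.0-fold higher number from compound 1 to compound 4 (0.01 log units; that floor lies within the scatter), so the true size of the change could be small or large.

On these data alone, how far the value of compound 4 lies past the limit stays open. So does how an amine or a carboxylic acid on this phenyl would read.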